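A few compounds are considered here, and "the series" means these few. Any claim that something is new, unique, unknown or untested is made for them only; others in the source may bear on it.

Working notes on the series. In a physicochemical assay for solubility, read by HPLC, at pH 7.4 (on this read-out higher numbers stand for higher solubility and lower numbers for lower solubility), compound 2 (`CCOCCCCc1cc(=O)c2ccccc2[nH]1`) gives > 200000 nM as a limit of the assay and not as a number. Its true position is therefore open on the upper side, and any step away from it can only be approximate. Compound 3 (`CCOCCCCc1cc(=O)c2cc(C(F)(F)F)ccc2[nH]1`) is the next compound to be read, and it takes trifluoromethyl in place of hydrogen on an aromatic carbon of the core of compound 2. Within the data shown here, no measured pair isolates this change. Among the measured compounds shown here, the only guide is compound 1 (`CCCCCOCc1cc(=O)c2cc(C(F)(F)F)ccc2[nH]1`) which also carries trifluoromethyl on a core of its own with a different chain, and which gives 15000 nM as a true number in this assay. On the strength of compound 1 alone a lower number is expected for compound 3, well beyond the usual scatter. The expected change is an at least 10-fold lower number from compound 2 to compound 3 (1.00 log units; beyond the scatter) as a drop and no more than an estimate. In this assay the estimate for compound 3 is 20000 nM within an expected range of 7000 nM to 60000 nM overall.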

Compound 3, solubility: > 200000 nM
Compound 3 ended at the assay's limit; the forecaster's own chance of this, stated with the estimate: 3%; middle value at least 10-fold (1.00 log units) away from the limit.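

In this assay, the pair with trifluoromethyl on both sides gives an at least 13-fold higher number from compound 1 to compound 3 (1.12 log units; beyond the scatter), with 3-ethoxypropyl in place of pentyloxy on a saturated chain carbon bound to an aromatic carbon. Compound 3 shares its trifluoromethyl-bearing core with compound 1, so a reading as low as that of compound 1 does not follow from trifluoromethyl at this position alone; within this pair, the chain is the one place that differs. The step for trifluoromethyl in place of hydrogen on the aromatic carbon cannot be read, because compound 2 and compound 3 both stand at the same limit and not at true numbers: the limit of > 200000 nM in this assay, at which 2 of the 3 values shown sit.

The compounds shown leave open how far apart compound 2 and compound 3 truly lie, and whether trifluoromethyl at this position moves the reading at all when the chain is 3-ethoxypropyl. Also open, going by these compounds, is whether a longer chain in place of 3-ethoxypropyl, or an amine in place of trifluoromethyl on the same aromatic carbon, would give a true number in this assay rather than a limit.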